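The source may hold more compounds than are shown below. What is called first, only, known or untested is meant among the compounds shown, and "the series" means these compounds.

In an ADME assay on microsomes from liver (Homo sapiens) for metabolic stability, tested at 2.5 uM; on this read-out higher numbers stand for fast clearance and lower numbers for slow clearance:
compound 1 `Cc1ccc(S(=O)(=O)c2cnc3c(F)cccc3c2-c2ccc(Cl)cc2)cc1F` gives 2.2 mL/min
compound 2 `O=S(=O)(c1cccc(F)c1)c1cnc2c(F)cccc2c1-c1ccc(Cl)cc1` gives 0.62 mL/min
compound 3 `O=S(=O)(c1cc(F)cc(F)c1)c1cnc2c(F)cccc2c1-c1ccc(Cl)cc1` gives 0.73 mL/min

Compound 2 stands at the low end of the three together with compound 3, a 1.2-fold higher number from compound 2 to compound 3 (0.07 log units; within the scatter); compound 1 lies well apart, a 3.5-fold lower number from compound 1 to compound 2 (0.55 log units; beyond the scatter). The remaining measured step, a 3.0-fold lower number from compound 1 to compound 3 (0.48 log units; beyond the scatter), also concerns only the group on the sulfonyl sulfur. Compound 4 `COc1cccc(-c2c(S(=O)(=O)c3cccc(F)c3)cnc3c(F)cccc23)c1` differs from compound 2 at another place: 3-methoxyphenyl in place of 4-chlorophenyl on an aromatic carbon. None of the three measured steps touches this position, so they give no direction for the change. With only the spread of the set as a guide, the step is expected to stay within the scatter, a 1.5-fold higher number from compound 2 to compound 4 (0.16 log units; within the scatter), with room either way. Compound 4 is therefore estimated at 0.9 mL/min, from 0.4 mL/min to 2.2 mL/min.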

Compound 4, intrinsic clearance in a liver preparation (reported as CLH), per the amount of preparation that the assay uses: 2.6 mL/min
Beside the measured number, compound 4's estimate is 2.9-fold (0.46 log units) below it; the whole stated range lies below it.
By their numbers in this assay, from the lowest: compounds 2 and 3 (each within the scatter of the next); then compounds 1 and 4 (each within the scatter of the next).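

This position is not silent in this assay: 3-methoxyphenyl in place of 4-chlorophenyl gives a 4.2-fold higher number from compound 2 to compound 4 (0.62 log units; beyond the scatter), a step beyond the scatter. The number therefore moves with a change on this aromatic carbon, opposite the ring nitrogen, as it does with changes on the sulfonyl sulfur. The swap alters both the substituent and its place on the phenyl ring, so the step cannot be assigned to either alone.

Going by these compounds, whether 3-chlorophenyl, 4-methoxyphenyl or an aminophenyl group here would follow compound 2 or compound 4 remains open. Nothing available accounts for the step.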